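The source may hold more compounds than are shown below. What is called first, only, known or untested is meant among the compounds shown, and "the series" means these compounds.

Measured so far:
- compound 1 `O=C(/C=C/c1ccc2c(c1)B(O)OC2)c1ccc(-c2ccccc2)cc1`: 20700 nM
- compound 2 `O=C(/C=C/c1ccc2c(c1)B(O)OC2)c1cccs1`: 13800 nM

In a toxicity assay on MCF-10A cells (Homo sapiens) for cytotoxicity, read by MTT assay, with a stated time of 48 h (a higher number here means a weaker inhibitor, a lower number a stronger inhibitor), compound 1 gives 20700 nM, the larger of the two numbers; compound 2 gives 13800 nM, a gap within the usual scatter, so the two are not separated. Compound 3 `O=C(/C=C/c1ccc2c(c1)B(O)OC2)c1ccc(I)cc1` is not yet measured. It differs from compound 1 by iodo in place of phenyl on an aromatic carbon. Going by the values given here, no step between measured compounds in this assay is available to guide the size of this change, and the two measured values leave little room either way. The expected step from compound 1 to compound 3 is a 1.2-fold lower number from compound 1 to compound 3 (0.06 log units; within the scatter), within the scatter. Compound 3 is estimated at 18000 nM, between 8000 nM and 45000 nM.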

Compound 3, half-maximal inhibitory concentration: > 100000 nM
Compound 3 gave a limit, no number (the forecaster's own chance of this, stated with the estimate: 10%); middle value at least 5.5-fold (0.74 log units) from the limit.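

In this assay, the phenyl position on this aromatic carbon is not indifferent: iodo in place of phenyl gives an at least 4.8-fold higher number from compound 1 to compound 3 (0.68 log units; beyond the scatter), and 4-iodophenyl in place of thiophen-2-yl on the carbonyl carbon gives an at least 7.2-fold higher number from compound 2 to compound 3 (0.86 log units; beyond the scatter). Going by these compounds alone, compound 1 and compound 2 were not separated, so these are the first steps beyond the scatter. The entry for compound 3 is a limit of the assay and not a number: the limit of > 100000 nM in this assay, at which 1 of the 3 values shown sits.

Going by these compounds, the true size of both steps stays open. Also open, on these data alone, is whether an amine or a methoxy group on this aromatic carbon would read like compound 1 or like compound 3.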